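A few compounds are considered here, and "the series" means these few. Any claim that something is new, unique, unknown or untested is made for them only; others in the source may bear on it.

The shared core is held fixed throughout; what changes is the aryl group on the sulfonyl sulfur. Compound 1 `COc1ccc(NS(=O)(=O)c2cccc(C#N)c2)cc1N1CCN(C)CC1` carries a 3-cyanophenyl there, and in an assay on HeLa cells for binding affinity to 5-hydroxytryptamine receptor 6 (Homo sapiens) (on this read-out higher numbers stand for weaker inhibition and lower numbers for stronger inhibition), compound 1 gives 63.1 nM. Compound 2 `COc1ccc(NS(=O)(=O)c2cc(Cl)cc(Cl)c2)cc1N1CCN(C)CC1` carries a 3,5-dichlorophenyl, and in this assay compound 2 gives 2 nM, a step of a 32-fold lower number from compound 1 to compound 2 (1.50 log units; beyond the scatter). For the measured compounds named here, compound 3 `COc1ccc(NS(=O)(=O)c2cc(I)ccc2C)cc1N1CCN(C)CC1` carries a 5-iodo-2-methylphenyl; in this assay compound 3 gives 1 nM, the lowest number of the three as written, though the step of a 2.0-fold lower number from compound 2 to compound 3 (0.30 log units; within the scatter) lies within the scatter and only the step of a 63-fold lower number from compound 1 to compound 3 (1.80 log units; beyond the scatter) lies beyond it.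

Compound 4 `COc1ccc(NS(=O)(=O)c2cccc(I)c2)cc1N1CCN(C)CC1` differs from compound 3 by hydrogen in place of methyl on an aromatic carbon. Going by the values given here, none of the measured steps removes a methyl in this way, so no direct guide exists. What the numbers do show is that compound 2, whose aryl group carries halogens and no methyl, sits within the scatter of compound 3, so the methyl is not needed to reach this region. The step expected for compound 4 is a 2.0-fold higher number from compound 3 to compound 4 (0.30 log units; within the scatter), not beyond the scatter. The estimate for compound 4 in this assay is 2 nM, with a range from 0.7 nM to 6 nM.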

Compound 4, inhibition constant: 0.794 nM
The estimate for compound 4 lay 2.5-fold (0.40 log units) above the measured number; the range from low to high includes it.
By their numbers in this assay, from the lowest: compounds 4, 3 and 2 (each within the scatter of the next, the first and the last beyond it); then compound 1.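

Taking the methyl off the 5-iodo-2-methylphenyl to leave 3-iodophenyl gives a 1.3-fold lower number from compound 3 to compound 4 (0.10 log units; within the scatter), so in this assay this change on an aromatic carbon leaves the number where it was, and the methyl is not needed once the iodo group is present. The other two steps place the iodo group itself: iodo in place of cyano gives a 79-fold lower number from compound 1 to compound 4 (1.90 log units; beyond the scatter), the only listed step that swaps one group for another with the rest of the aryl group unchanged, while 3-iodophenyl in place of 3,5-dichlorophenyl gives a 2.5-fold lower number from compound 2 to compound 4 (0.40 log units; beyond the scatter), a modest step but one beyond the scatter. Nothing given here offers an explanation for why these aryl groups differ as they do.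

The compounds shown leave open how much of this depends on iodo specifically, since the picture holds no aryl group carrying bromo, methoxy or an amine in that place, and no plain phenyl. On these data alone, it also remains open whether a group larger than methyl, such as ethyl or isopropyl, would be accepted on that same aromatic carbon.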